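Cyclopentyloxy in Place of Dichlorophenyl on a Sulfonyl Acylguanidine

The source may report more compounds than this note shows. Statements on the series, on what has been measured and on what is new or still open speak of the compounds shown alone.

Compound 1 `CCc1cc(Br)c(S(C)(=O)=O)cc1C(=O)N=C(N)N` and compound 2 `Cc1cc(-c2ccc(Cl)cc2Cl)c(S(C)(=O)=O)cc1C(=O)N=C(N)N` share the same core. In a functional assay for inhibition of sodium/hydrogen exchanger (Oryctolagus cuniculus) (a higher number here means a weaker inhibitor, a lower number a stronger inhibitor), compound 1 gives 41 nM, and compound 2 gives 42 nM. Compound 2 thus sits alongside compound 1, the gap between them lying within the scatter. Compound 3 `Cc1cc(OC2CCCC2)c(S(C)(=O)=O)cc1C(=O)N=C(N)N` follows from compound 2 by a single change: cyclopentyloxy in place of 2,4-dichlorophenyl on an aromatic carbon. Going by the values given here, no measured pair carries this change, so no step for it is known. The estimate for compound 3 in this assay is 75 nM, with a range from 25 nM to 220 nM. The step of a 1.8-fold higher number from compound 2 to compound 3 (0.25 log units; within the scatter) is expected to be modest, toward a weaker inhibitor, barely beyond the scatter.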

Compound 3, half-maximal inhibitory concentration: 27 nM
Beside the measured number, compound 3's estimate is 2.8-fold (0.44 log units) above it; the range from low to high includes it.
By their numbers in this assay, from the lowest: compounds 3, 1 and 2 (each within the scatter of the next).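

In this assay the exchange gives a 1.6-fold lower number from compound 2 to compound 3 (0.19 log units; within the scatter), so this position, ortho to a methylsulfonyl group, carries either an aromatic 2,4-dichlorophenyl or a non-aromatic cyclopentyloxy with no difference beyond the scatter. The entering group also brings one hydrogen-bond acceptor where the leaving group has none, and the number still stays within the scatter. Nothing available gives a reason for this result. The compounds shown leave open whether an amine, a carboxylic acid or a longer alkoxy chain at this position would keep the number in the same range.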